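Swapping an aryl group for an ester-bearing chain

The source may hold more compounds than are shown below. What is called first, only, known or untested is meant among the compounds shown, and "the series" means these compounds.

Measured so far:
- compound 1, `CCOC(=O)CN(Cc1ccccc1)c1nc(NCc2cccc(OC)c2)ncc1[N+](=O)[O-]`: in a functional assay on MCF7 cells (Homo sapiens) for antiproliferative activity, read by MTT assay, with a stated time of 48 h (a higher number here means a weaker inhibitor, a lower number a stronger inhibitor), compound 1 gives 57400 nM.
- compound 2, `CCOC(=O)CN(Cc1ccccc1)c1nc(Nc2ccccc2)ncc1[N+](=O)[O-]`: in this assay compound 2 gives > 100000 nM, which is a limit of the assay and not a number.
- compound 3, `CCOC(=O)CN(Cc1ccccc1)c1nc(Nc2cc(OC)c(OC)c(OC)c2)ncc1[N+](=O)[O-]`: in this assay compound 3 gives > 100000 nM, again a limit of the assay.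

Compound 3 therefore stands at the edge of what this assay can report, and it shares that position with one other compound, as the limit of > 100000 nM in this assay, at which 2 of the 3 values shown sit, records. The step from compound 1 to compound 3 is an at least 1.7-fold higher number from compound 1 to compound 3 (0.24 log units; that floor lies within the scatter), and the step from compound 1 to compound 2 is an at least 1.7-fold higher number from compound 1 to compound 2 (0.24 log units; that floor lies within the scatter); between compound 2 and compound 3 the step is a step that the two limits leave unreadable from compound 2 to compound 3. Among the compounds with values here, the only change that has moved the number at all is the loss of the 3-methoxybenzyl group.

Compound 4, `CCOC(=O)CNc1ncc([N+](=O)[O-])c(N(CC(=O)OCC)Cc2ccccc2)n1`, is not yet measured. It differs from compound 3 in one place: (ethoxycarbonyl)methyl in place of 3,4,5-trimethoxyphenyl on a nitrogen on an aromatic ring. Within the data shown here, none of the measured steps tests an open chain at this nitrogen, so they offer only a weak guide, and compound 3 already sits at the limit. For compound 4 in this assay a step of a number no higher from compound 3 to compound 4 (the limit leaves the size open) is expected, with a real chance that the assay again reports only a limit. The estimate for compound 4 is 100000 nM, between 40000 nM and 250000 nM.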

Compound 4, half-maximal inhibitory concentration: > 100000 nM
Compound 4 was reported as a limit (the forecaster's own chance of this, stated with the estimate: 60%); the middle value sits exactly at the limit.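

Unlike compound 1, compound 2 and compound 3, compound 4 carries an open chain with no ring, (ethoxycarbonyl)methyl, on this nitrogen, and in this assay compound 4 gives > 100000 nM, which is a limit of the assay and not a number. Within the data shown here, measured against the only compound with a number, replacing 3-methoxyphenyl with ethoxycarbonyl on the saturated chain carbon gives an at least 1.7-fold higher number from compound 1 to compound 4 (0.24 log units; that floor lies within the scatter), so the true size of this step stays open, while the steps to compound 4 from compound 2 and compound 3 cannot be read at all. Among these compounds, a ring directly on this nitrogen and an ester chain without a ring have now both ended at the edge of what the assay reports, leaving compound 1 as the only compound with a number: the limit of > 100000 nM in this assay, at which 3 of the 4 values shown sit.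

The compounds shown leave open how far the true values of compound 2, compound 3 and compound 4 lie from that limit. Also open, on these data alone, is whether a carboxylic acid in place of the ester, or an amine at the end of a longer chain, would bring a value back within the range of the assay.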